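Dropping the Trifluoromethyl: Expected Cytotoxicity of Compound 4

A few compounds are considered here, and "the series" means these few. Any claim that something is new, unique, unknown or untested is made for them only; others in the source may bear on it.

Of the compounds shown here, three built on one shared core have been measured in an ADME assay on MCF-10A cells (Homo sapiens) for cytotoxicity, read by MTT assay, with a stated time of 24 h; a higher number here means a weaker inhibitor, a lower number a stronger inhibitor. Compound 1 `Fc1ccc(-n2cc(COc3ccccc3-c3nc4ccccc4s3)nn2)cc1Cl` gives 26300 nM. Compound 2 `Fc1ccc(-n2cc(COc3ccccc3-c3nc4ccccc4s3)nn2)cc1` gives 33300 nM in this assay. Compound 3 `FC(F)(F)c1cccc(-n2cc(COc3ccccc3-c3nc4ccccc4s3)nn2)c1` gives 31100 nM in this assay. Among these three numbers compound 3 holds the second highest; its nearest neighbour is reached by the step of a 1.1-fold lower number from compound 2 to compound 3 (0.03 log units; within the scatter) and its furthest by the step of a 1.2-fold higher number from compound 1 to compound 3 (0.07 log units; within the scatter), and both of these lie within the scatter of repeated measurements.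

Compound 4 `c1ccc(-n2cc(COc3ccccc3-c3nc4ccccc4s3)nn2)cc1` differs from compound 3 by hydrogen in place of trifluoromethyl on an aromatic carbon. The measured steps that bear on this change are the ones in which the same aromatic ring was altered: a 1.3-fold higher number from compound 1 to compound 2 (0.10 log units; within the scatter), a 1.2-fold higher number from compound 1 to compound 3 (0.07 log units; within the scatter) and a 1.1-fold lower number from compound 2 to compound 3 (0.03 log units; within the scatter). None of them rises beyond the scatter, whether a halogen is removed or one substituted ring is exchanged for another. On that basis the expected step for compound 4 is a 1.0-fold lower number from compound 3 to compound 4 (0.00 log units; within the scatter), with no shift beyond the scatter in either direction. The estimated value for compound 4 in this assay is therefore 31000 nM, with a range from 15000 nM to 62000 nM.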

Compound 4, half-maximal inhibitory concentration: 36400 nM
Compound 4: middle estimate off by 1.2-fold (0.07 log units), on the low side, within the range that was stated.
By their numbers in this assay, from the lowest: compounds 1, 3, 2 and 4 (each within the scatter of the next).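

In this assay, among the compounds shown here, the plain phenyl on the aromatic nitrogen gives the unsubstituted reference that the earlier compounds lacked: hydrogen in place of trifluoromethyl gives a 1.2-fold higher number from compound 3 to compound 4 (0.07 log units; within the scatter) and hydrogen in place of fluoro gives a 1.1-fold higher number from compound 2 to compound 4 (0.04 log units; within the scatter). Even stripping the ring of both its halogens, with phenyl in place of 3-chloro-4-fluorophenyl, gives a 1.4-fold higher number from compound 1 to compound 4 (0.14 log units; within the scatter) and so stays inside the scatter, which means that across these four compounds neither the presence nor the kind of substituent on this ring separates one number from another in this assay. Nothing available here accounts for this flat picture.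

The compounds shown leave open whether an amine or a carboxylic acid on this ring would also stay within the scatter or would move the number beyond it, since only halogens and trifluoromethyl have been compared with hydrogen here. They also leave open whether a change elsewhere on the shared core, which is identical in all four compounds, would matter more than any change on this ring.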